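Compound 3: a diethylamino chain in place of hydroxy

The compounds below may be only part of what the source reports. "The series", "measured", "known", "first", "only" and "open" are said of these compounds alone.

In a functional assay on HL60/MX2 cells (Homo sapiens) for antiproliferative activity, read by MTT assay, with a stated time of 48 h (a higher number here means a weaker inhibitor, a lower number a stronger inhibitor), compound 2 `N#Cc1nc2c(-c3nc4ccccc4[nH]3)c(N)n(CCO)c2nc1C#N` stands at > 50000 nM, which is a limit of the assay and not a number. Compound 1 `CCN(CC)CCn1c(N)c(-c2nc3ccccc3[nH]2)c2nc(C#N)c(C#N)nc21` reads 7150 nM. Compound 3 `CCN(CC)CCCn1c(N)c(-c2nc3ccccc3[nH]2)c2nc(C#N)c(C#N)nc21` replaces 2-hydroxyethyl with 3-(diethylamino)propyl, a change counted as (diethylamino)methyl in place of hydroxy on a saturated chain carbon, two bonds along the chain from an aromatic nitrogen. Only an at least 6.9-fold higher number from compound 1 to compound 2 (0.84 log units; beyond the scatter) bears on this change, and that step lies beyond the scatter. Read in reverse, with a diethylamino group back on the chain, it points to a lower number in this assay. The expected step is an at least 8.3-fold lower number from compound 2 to compound 3 (0.92 log units; beyond the scatter). Compound 3 is estimated at 6000 nM, with an expected range of 2000 nM to 20000 nM.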

Compound 3, half-maximal inhibitory concentration: 1820 nM
Estimate against measurement, compound 3: 3.3-fold (0.52 log units) above; the whole stated range lies above it.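

In this assay, the position still responds once diethylamino is on the chain: moving to 3-(diethylamino)propyl gives a 3.9-fold lower number from compound 1 to compound 3 (0.59 log units; beyond the scatter), so chain length moves the number as well as the end group. Against the 2-hydroxyethyl chain, the same group gives an at least 27-fold lower number from compound 2 to compound 3 (1.43 log units; beyond the scatter). The size of that step rests on compound 2, whose value is a limit of the assay and not a number: the limit of > 50000 nM in this assay, at which 1 of the 3 values shown sits.

Going by these compounds, whether a longer chain, such as 4-(diethylamino)butyl, lowers the number further remains open. So does whether a cyclic amine such as morpholine can stand in for diethylamino at the chain end.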